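Moving a hydroxyl on a shared pyridine core

A few compounds are considered here, and "the series" means these few. Any claim that something is new, unique, unknown or untested is made for them only; others in the source may bear on it.

Two compounds share the same core and differ only in their outer aromatic groups. Compound 1 `Oc1ccc(-c2cc(-c3cccs3)cc(-c3cccc(O)c3)n2)cc1` carries a 4-hydroxyphenyl, a thiophen-2-yl and a 3-hydroxyphenyl group. In a functional assay on HCT-15 cells (Homo sapiens) for cytotoxicity, read by CCK-8 assay (on this read-out lower numbers stand for stronger inhibition and higher numbers for weaker inhibition), compound 1 gives 1770 nM. Compound 2 `Oc1ccc(-c2cc(-c3ccco3)cc(-c3ccccc3O)n2)cc1` carries a furan-2-yl and a 2-hydroxyphenyl group instead. In this assay compound 2 gives only a limit of > 50000 nM, which is the edge of what the test can report and not a number. Where compound 2 stands among the numbers shown is therefore only known as the limit of > 50000 nM in this assay, at which 1 of the 2 values shown sits. Compound 3 `Oc1ccc(-c2cc(-c3ccco3)cc(-c3cccc(O)c3)n2)cc1` has not yet been measured. It is built from compound 2 by the change (3-hydroxyphenyl in place of 2-hydroxyphenyl on an aromatic carbon), which puts a 3-hydroxyphenyl in place of a 2-hydroxyphenyl on an aromatic carbon. Because compound 1, which also carries a 3-hydroxyphenyl group, gives 1770 nM, the step from compound 2 to compound 3 is expected to be large and toward stronger inhibition, well beyond the usual scatter, at about an at least 14-fold lower number from compound 2 to compound 3 (1.15 log units; beyond the scatter). Compound 3 is expected to give about 3500 nM, within a range from 1000 nM to 20000 nM.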

Compound 3, half-maximal inhibitory concentration: 840 nM
Compound 3: middle estimate off by 4.2-fold (0.62 log units), on the high side; the whole stated range lies above it.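

The 2-hydroxyphenyl and 3-hydroxyphenyl groups have the same atoms, and this pair isolates where the hydroxyl sits on that outer ring, with the furan-2-yl group and the rest of the molecule unchanged; in this assay, the move gives an at least 59-fold lower number from compound 2 to compound 3 (1.77 log units; beyond the scatter). The size of that step rests on a value for compound 2 that is a limit and not a number: the limit of > 50000 nM in this assay, at which 1 of the 3 values shown sits. Compound 3 also forms a one-place pair with compound 1, which keeps the 3-hydroxyphenyl group and exchanges only the other ring, and furan-2-yl in place of thiophen-2-yl gives a 2.1-fold lower number from compound 1 to compound 3 (0.32 log units; beyond the scatter), a modest step beside the large one from the hydroxyl move.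

From the compounds shown here alone, whether the hydroxyl move has a similar effect when thiophen-2-yl replaces furan-2-yl remains open, as the 2-hydroxyphenyl group appears here only alongside furan-2-yl. Also open, going by these compounds, is what a methoxy group or an amine would do in place of the hydroxyl on the 3-hydroxyphenyl group, and whether the hydroxyl of the 4-hydroxyphenyl group matters at all.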